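Carbonyl substituent change from compound 2 to compound 3

A few compounds are considered here, and "the series" means these few. Any claim that something is new, unique, unknown or untested is made for them only; others in the source may bear on it.

Measured in a functional assay on a cell-free system (Platelet, plasma, Homo sapiens) for inhibition, read by turbidimetry, with a stated time of 3 min; a lower number here means a stronger inhibitor, a higher number a weaker inhibitor:
- compound 1 `COc1ccc(NC(=O)c2cc(-c3ccc(Cl)cc3)n(-c3ccc(OC)nn3)n2)cc1`: 400 nM
- compound 2 `COc1ccc(-n2nc(C(=O)OCCC(C)C)cc2-c2ccc(Cl)cc2)nn1`: 1330 nM

Of the two measured compounds, compound 2 has the higher number, at 1330 nM, and compound 1 stands at 400 nM. The next compound, compound 3 `COc1ccc(-n2nc(C(=O)N3CCCC3)cc2-c2ccc(Cl)cc2)nn1`, carries pyrrolidin-1-yl in place of isopentyloxy on a carbonyl carbon. Cut one bond further out, the same difference reads isopentyloxycarbonyl to (pyrrolidin-1-yl)carbonyl.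

Among the measured compounds shown here, only one measured step bears on this change: a 3.3-fold higher number from compound 1 to compound 2 (0.52 log units; beyond the scatter). That modest step, beyond the scatter, went from (4-methoxyphenyl)amino to isopentyloxy on the same carbonyl carbon. Compound 3 also replaces isopentyloxy with a group attached through nitrogen, so the direction of that step is read in reverse. For the measured compounds named here, no measured compound carries pyrrolidin-1-yl, so this guide is weak, and a step of similar or smaller size is expected. The estimated step in this assay is a 2.2-fold lower number from compound 2 to compound 3 (0.35 log units; beyond the scatter). For compound 3 the expected value is 600 nM, with an estimated range of 130 nM to 2800 nM.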

Compound 3, half-maximal inhibitory concentration: 15 nM
Beside the measured number, compound 3's estimate is 40-fold (1.60 log units) above it; measured number outside the range, below it.
By their numbers in this assay, from the lowest: compound 3; then compound 1; then compound 2.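

In this assay, the group on the carbonyl carbon proves able to move the number much further than the earlier pair showed: pyrrolidin-1-yl in place of isopentyloxy gives an 89-fold lower number from compound 2 to compound 3 (1.95 log units; beyond the scatter), a large step against the modest 3.3-fold higher number from compound 1 to compound 2 (0.52 log units; beyond the scatter). Pyrrolidin-1-yl in place of (4-methoxyphenyl)amino also gives a large change, a 27-fold lower number from compound 1 to compound 3 (1.43 log units; beyond the scatter), so attachment through nitrogen does not by itself set the number among these compounds, since compound 1 and compound 3 both carry it and still stand well apart. Nothing available here explains the size of either step.

Open, from the compounds shown here alone, is whether the gain belongs to the five-membered ring specifically or would also appear with piperidin-1-yl, morpholin-4-yl or an open-chain diethylamino group on the same carbonyl carbon. Also open, going by these compounds, is how a small secondary amide, such as methylamino in that place, would stand against compound 1 and compound 3, which would help separate the effect of the aryl group in compound 1 from that of the amide hydrogen.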